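Chain extension on two aryl cores

The compounds below may be only part of what the source reports. "The series", "measured", "known", "first", "only" and "open" are said of these compounds alone.

Compound 1 `CCCCCCCc1ccc(-c2c(C)[nH]c(=O)n2C)cc1` and compound 2 `CCCCCCCOc1ccc(-c2c(C)[nH]c(=O)n2C)cc1` carry the same chain-bearing part; the difference between the two cores is not broken down here. In a functional assay on brain (Rattus norvegicus, strain Wistar) for inhibition (a lower number here means a stronger inhibitor, a higher number a weaker inhibitor), compound 1 gives 8400 nM, and compound 2 gives 5700 nM. Compound 3 `CCCCCCCCc1ccc(-c2c(C)[nH]c(=O)n2C)cc1` differs from compound 1 by methyl in place of hydrogen on a saturated chain carbon, seven bonds along the chain from an aromatic carbon. In this assay compound 3 gives 19400 nM, which is a 2.3-fold higher number from compound 1 to compound 3 (0.36 log units; beyond the scatter).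

Compound 4 `CCCCCCCCOc1ccc(-c2c(C)[nH]c(=O)n2C)cc1` has not yet been measured. It differs from compound 2 by methyl in place of hydrogen on a saturated chain carbon, seven bonds along the chain from an oxygen on an aromatic ring. Around the place the two changes differ: in compound 1 the chain carbon lies seven bonds along the chain from an aromatic carbon, in compound 2 seven bonds along the chain from an oxygen on an aromatic ring, so this is the same kind of change, not the same one. Among the compounds with values here, the only measured instance of this kind of change is a 2.3-fold higher number from compound 1 to compound 3 (0.36 log units; beyond the scatter). For compound 4 a step of similar size is expected, a 2.1-fold higher number from compound 2 to compound 4 (0.32 log units; beyond the scatter), resting on that single pair and on nothing else. Compound 4 is therefore estimated at 12000 nM, with a range from 6000 nM to 25000 nM.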

Compound 4, half-maximal inhibitory concentration: 4000 nM
Estimate against measurement, compound 4: 3.0-fold (0.48 log units) above, outside the stated range (below it).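

In this assay, the added methyl does not carry over from one core to the other with the same result: the same change on two cores in this assay, a 2.3-fold higher number (0.36 log units; beyond the scatter) from compound 1 to compound 3 and a 1.4-fold lower number (0.15 log units; within the scatter) from compound 2 to compound 4, 3.3-fold (0.52 log units) apart, beyond the scatter of two such steps

On the core of compound 2 the step is a 1.4-fold lower number from compound 2 to compound 4 (0.15 log units; within the scatter), so this core shows no change beyond the scatter, whereas the core of compound 1 gives a 2.3-fold higher number from compound 1 to compound 3 (0.36 log units; beyond the scatter). This shows that a step measured on one core in this series cannot simply be transferred to the other, but with a single pair per core it does not show what sets the two cores apart, nor how either core responds to any other change to the chain.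

The compounds shown leave open whether a longer chain would widen, narrow or reverse the gap between the two cores. They also leave open how either core would respond if an amine or a carboxylic acid replaced the saturated chain.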